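This account rests on a few compounds, and the source may have more. Where it says the series, first, only, none or still open, it means among the compounds named here.

Measured so far in an assay for inhibition of Amine oxidase [flavin-containing] B (Rattus norvegicus); a lower number here means a stronger inhibitor, a higher number a weaker inhibitor:
Compound 1 `C[C@H](Nc1cc(=O)oc2cc(OCc3ccccc3)ccc12)C(N)=O` — 680 nM
Compound 2 `NC(=O)[C@@H]1CCCN1c1cc(=O)oc2cc(OCc3ccccc3)ccc12` — 16100 nM
Compound 3 `CC(C(N)=O)c1cc(=O)oc2cc(OCc3ccccc3)ccc12` — 100 nM

Compound 3 has the lowest number of the three, set apart from both others beyond the scatter: a 6.8-fold lower number from compound 1 to compound 3 (0.83 log units; beyond the scatter) and a 160-fold lower number from compound 2 to compound 3 (2.21 log units; beyond the scatter). Compound 4 `CN(C)Cc1cc(=O)oc2cc(OCc3ccccc3)ccc12` changes the same position once more: (dimethylamino)methyl in place of 1-carbamoylethyl on an aromatic carbon. The two measured steps at this position each replaced one carboxamide-bearing group by another, so none of them shows what happens when the carboxamide is removed altogether; they bear on compound 4 only in showing that this position moves the number a lot. Without a direct precedent, the step is expected to be upward and sizeable, a 15-fold higher number from compound 3 to compound 4 (1.18 log units; beyond the scatter), with a wide range. Compound 4 is estimated at 1500 nM (range 300 nM to 8000 nM).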

Compound 4, half-maximal inhibitory concentration: 1800 nM
Beside the measured number, compound 4's estimate is 1.2-fold (0.08 log units) below it; low and high end bracket the measured number.
By their numbers in this assay, from the lowest: compound 3; then compound 1; then compound 4; then compound 2.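

Taking the carboxamide out at this position, with (dimethylamino)methyl entering in place of 1-carbamoylethyl, costs a lot in this assay (an 18-fold higher number from compound 3 to compound 4 (1.26 log units; beyond the scatter)). Yet the group without a carboxamide lands inside the span of the carboxamide-bearing groups, better than 2-carbamoylpyrrolidin-1-yl (an 8.9-fold lower number from compound 2 to compound 4 (0.95 log units; beyond the scatter)) and worse than (1-carbamoylethyl)amino (a 2.6-fold higher number from compound 1 to compound 4 (0.42 log units; beyond the scatter)), so a carboxamide alone does not set the number here. No measurement at hand accounts for these steps.

Still open, from the compounds shown here alone, is how a plain ethyl group or a carboxylic acid would compare with 1-carbamoylethyl at this position. Also open, going by these compounds, is whether a longer chain carrying the dimethylamino group moves the number further.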